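The source may hold more compounds than are shown below. What is called first, only, known or untested is meant among the compounds shown, and "the series" means these compounds.

Measured in a functional assay on MDA-MB-231 cells (Homo sapiens) for antiproliferative activity, read by MTT assay, with a stated time of 72 h; on this read-out lower numbers stand for stronger inhibition and higher numbers for weaker inhibition:
Compound 1 `COc1cc(-c2nccn2C)cc(OC)c1OC`: > 100000 nM (a limit, not a number)
Compound 2 `COc1cc(-c2nccn2-c2ccc(F)cc2)cc(OC)c1OC`: 38400 nM

Among the measured compounds shown here, compound 2 holds the only true number so far. Compound 3 `COc1cc(-c2nccn2-c2ccc(Br)cc2)cc(OC)c1OC` differs from it in one place: bromo in place of fluoro on an aromatic carbon. For the measured compounds named here, the single measured step, an at least 2.6-fold lower number from compound 1 to compound 2 (0.41 log units; beyond the scatter), concerns a different place, 4-fluorophenyl in place of methyl on an aromatic nitrogen. That step also starts from a limit, (the limit of > 100000 nM in this assay, at which 1 of the 2 values shown sits), so it offers little guidance here. No change beyond the scatter is therefore expected in this assay. The expected step is a 1.5-fold lower number from compound 2 to compound 3 (0.19 log units; within the scatter). Compound 3 is estimated at 25000 nM, with an expected range of 8000 nM to 80000 nM.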

Compound 3, half-maximal inhibitory concentration: 8400 nM
Estimate against measurement, compound 3: 3.0-fold (0.47 log units) above; low and high end bracket the measured number.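

In this assay, the group on the 4-phenyl ring clearly affects the result: bromo in place of fluoro gives a 4.6-fold lower number from compound 2 to compound 3 (0.66 log units; beyond the scatter), so exchanging this single atom is enough to move the number beyond the usual scatter. Compound 1 is a limit, not a number, so the other comparison, 4-bromophenyl in place of methyl on the aromatic nitrogen, gives only a bound, an at least 11-fold lower number from compound 1 to compound 3 (1.07 log units; beyond the scatter): the limit of > 100000 nM in this assay, at which 1 of the 3 values shown sits.

From the compounds shown here alone, whether chloro, methoxy or an amine at this place would give a lower number than bromo remains open. Two groups also cannot show which difference between fluoro and bromo matters here.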